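From methoxy to methylamino on a shared core

The compounds below may be only part of what the source reports. "The series", "measured", "known", "first", "only" and "open" are said of these compounds alone.

- compound 1 `COc1ncnc2c1c(-c1cc3ccccc3o1)cn2[C@@H]1O[C@H](CO)[C@@H](O)[C@H]1O`: 10800 nM
- compound 2 `CSc1ncnc2c1c(-c1ccsc1)cn2[C@@H]1O[C@H](CO)[C@@H](O)[C@H]1O`: > 20000 nM (a limit)

Within the data shown here, in a functional assay on CEM-DNR-bulk cells (Homo sapiens), read by MTT assay, with a stated time of 72 h (on this read-out lower numbers stand for stronger inhibition and higher numbers for weaker inhibition), compound 1 gives 10800 nM, the only actual number available in this small set. Compound 2 is reported only as a limit, > 20000 nM. Compound 1 therefore stands alone as the one measured point, and the data offer no measured ladder on which to place it.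

The compound of interest is compound 3 `CNc1ncnc2c1c(-c1cc3ccccc3o1)cn2[C@@H]1O[C@H](CO)[C@@H](O)[C@H]1O`, which has not yet been tested in this assay. It keeps the core of compound 1 and carries methylamino in place of methoxy on an aromatic carbon. Among the measured compounds shown here, no measured pair in the set shows this exchange, so the expectation starts from the value of compound 1, 10800 nM, and assumes no clear direction. The expected change is a 1.2-fold lower number from compound 1 to compound 3 (0.08 log units; within the scatter), which is estimated to stay within the usual scatter, although the uncertainty is wide. The estimate for compound 3 is 9000 nM, with an expected range from 2500 nM to 20000 nM.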

Compound 3, half-maximal inhibitory concentration: > 20000 nM
Compound 3: no number, only a limit (the forecaster's own chance of this, stated with the estimate: 30%); middle value at least 2.2-fold (0.34 log units) away from the limit.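

In this assay, compound 3 is reported only as a limit, > 20000 nM. Among these compounds, this gives the first measured pair for a change on this aromatic carbon, next to the ring nitrogen, and putting methylamino in place of methoxy on the shared core gives an at least 1.8-fold higher number from compound 1 to compound 3 (0.26 log units; that floor lies within the scatter), so the exchange shows no sign of a lower number, although the floor of the step does not go beyond the scatter. The true size of the step cannot be read, and compound 1 remains the only compound with an actual number, so the result is bounded by this limit: the limit of > 20000 nM in this assay, at which 2 of the 3 values shown sit.

Compound 2 differs from compound 1 and compound 3 in more than one place, so it cannot show how methoxy, methylamino or any other group at this position contributes on its own. The compounds shown leave open how a plain amine, a longer chain such as ethoxy or a small group such as chlorine would read at this position, and whether methylamino would give the same result on a different core.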